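Halogen swap on the fluorophenyl arm of compound 1

The source may hold more compounds than are shown below. What is called first, only, known or untested is meant among the compounds shown, and "the series" means these compounds.

Compound 1 `CS(=O)(=O)c1ccc(-c2cnc3[nH]cc(-c4nnc(-c5ccc(F)cc5)o4)c(=O)c3c2)cc1` is tested in a functional assay on HCT-116 cells (Homo sapiens) for inhibition, read by MTT assay, with a stated time of 24 h, tested at 2.5 uM (a higher number here means more inhibition of growth at the concentration tested, a lower number less inhibition of growth), and gives 10.7%. Compound 2 `O=c1c(-c2nnc(-c3ccc(F)cc3)o2)c[nH]c2ncc(-c3cccnc3)cc12`, with pyridin-3-yl in place of 4-(methylsulfonyl)phenyl on an aromatic carbon, gives 9.87% in this assay. Among the compounds with values here, the only measured step, a number 0.8 percentage points lower from compound 1 to compound 2 (within the scatter), lies within the scatter, so the two numbers shown sit together and compound 1 is not set apart from compound 2.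

Compound 3 `CS(=O)(=O)c1ccc(-c2cnc3[nH]cc(-c4nnc(-c5ccc(Cl)cc5)o4)c(=O)c3c2)cc1` carries chloro in place of fluoro on an aromatic carbon, para to a large group on a six-membered aromatic ring of carbon only. Within the data shown here, no measured step touches this ring or this exchange; the one step known concerns a different aromatic carbon and was itself within the scatter. Nothing therefore supports a step beyond the scatter in either direction, and the expected step from compound 1 to compound 3 is a number 1.3 percentage points higher from compound 1 to compound 3 (within the scatter). Compound 3 is estimated at 12% in this assay, with a range from 0% to 28%.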

Compound 3, percent growth inhibition at one concentration: 2.06%
For compound 3 the middle estimate is 9.9 percentage points above the measured one; low and high end bracket the measured number.
By their numbers in this assay, from the lowest: compounds 3, 2 and 1 (each within the scatter of the next).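

Within the data shown here, replacing fluoro with chloro on the aromatic carbon of the 4-fluorophenyl arm gives a number 8.6 percentage points lower from compound 1 to compound 3 (within the scatter) in this assay and is the first reading at this position. This single exchange on the core of compound 1 does not separate compound 1 from compound 3, so the change from 4-fluorophenyl to 4-chlorophenyl shows no effect beyond the usual scatter at the concentration tested. No measurement available here bears on a cause for this result.

Still open, going by these compounds, is whether a different group at this place, such as an amine, a methoxy or a carboxylic acid, would stand apart from fluoro and chloro. On these data alone, it is also open whether chloro in place of fluoro reads the same when pyridin-3-yl replaces 4-(methylsulfonyl)phenyl.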